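This account rests on a few compounds, and the source may have more. Where it says the series, first, only, none or still open, it means among the compounds named here.

Measured so far:
compound 1 `COc1c(Br)cccc1C(=O)Nc1ccccc1` — > 100000 nM
compound 2 `O=C(Nc1ccccc1)c1cccc(Br)c1` — > 100000 nM
compound 3 `COc1ccccc1C(=O)Nc1ccc(Sc2nc3ccccc3s2)cc1` — > 100000 nM

In an assay on isolated protein for inhibition of thiosulfate sulfurtransferase (Homo sapiens), with a stated time of 60 min, in the absence of a further agent (on this read-out higher numbers stand for weaker inhibition and lower numbers for stronger inhibition), the value of compound 1 is a limit of the assay, not a number. The value of compound 2 in this assay is likewise a limit. The same holds for compound 3 in this assay, where the value is a limit. All three sit at the limit of > 100000 nM in this assay, at which 3 of the 3 values shown sit, so a step that the two limits leave unreadable from compound 1 to compound 2 is unreadable: the change hydrogen in place of methoxy on an aromatic carbon cannot be sized from these two.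

Compound 4 `O=C(Nc1ccc(Sc2nc3ccccc3s2)cc1)c1ccccc1` differs from compound 3 by hydrogen in place of methoxy on an aromatic carbon, the same kind of change as between compound 1 and compound 2, though the surroundings differ: in compound 1 the methoxy is ortho to a bromo group and ortho to a group of 9 heavy atoms, in compound 3 ortho to a large group. The difference between the cores of compound 1 and compound 3 is not broken down here.

For compound 4 the step of a number no higher from compound 3 to compound 4 (the limit leaves the size open) in this assay is expected to be small, resting on compound 3 at > 100000 nM and on the unreadable step from compound 1 to compound 2. Compound 4 is estimated at 100000 nM in this assay, between 30000 nM and 300000 nM, most likely again only a limit.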

Compound 4, half-maximal inhibitory concentration: > 100000 nM
Compound 4: a limit, no number; the forecaster's own chance of this, stated with the estimate: 85%; the middle value lies on the limit itself.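

No step can be read between compound 3 and compound 4 in this assay: both values are limits. The compounds shown leave open whether hydrogen in place of methoxy changes inhibition at all, in either core.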